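Cutting the cyclohexyl group of compound 1 to isopropyl

A few compounds are considered here, and "the series" means these few. Any claim that something is new, unique, unknown or untested is made for them only; others in the source may bear on it.

In a functional assay on CAL-51 cells (Homo sapiens) for antiproliferative activity, read by luminescence and CellTiter-Glo, with a stated time of 3 days (a higher number here means a weaker inhibitor, a lower number a stronger inhibitor), compound 1 (`COc1cc(C(=O)N(C)C)ccc1Nc1nc(OC2CCCCC2)c2cc[nH]c2n1`) gives 190 nM as the highest of the three measured numbers, which makes it the weakest inhibitor of the group. Compound 3 (`COc1cc(N2CCN(C3COC3)CC2)ccc1Nc1nc(O[C@H]2CCOC(C)(C)C2)c2cc[nH]c2n1`) gives 84 nM and compound 2 (`CN(C)C(=O)c1ccc(Nc2nc(O[C@H]3CC[C@@](C)(O)CC3)c3cc[nH]c3n2)c(OCC(F)(F)F)c1`) gives 15 nM with both lying beyond the scatter on the stronger side of compound 1. Neither differs from compound 1 in one place only, so neither isolates a single change.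

Compound 4 (`COc1cc(C(=O)N(C)C)ccc1Nc1nc(OC(C)C)c2cc[nH]c2n1`), not yet measured, carries isopropyl in place of cyclohexyl on an oxygen on an aromatic ring. Going by the values given here, no measured pair shows this change, and the expectation therefore starts from compound 1 at 190 nM with wide uncertainty. In this assay a moderate move towards a higher number, meaning a weaker inhibitor, is expected, although a result within the scatter remains possible. The estimated step runs a 2.4-fold higher number from compound 1 to compound 4 (0.37 log units; beyond the scatter) as a tentative expectation. Compound 4 is expected at 450 nM (estimated range 150 nM to 1400 nM).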

Compound 4, half-maximal inhibitory concentration: 1270 nM
Compound 4: middle estimate off by 2.8-fold (0.45 log units), on the low side, within the range that was stated.
By their numbers in this assay, from the lowest: compound 2; then compound 3; then compound 1; then compound 4.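

Going by these compounds alone, replacing cyclohexyl with isopropyl on an oxygen on an aromatic ring gives, in this assay, a 6.7-fold higher number from compound 1 to compound 4 (0.83 log units; beyond the scatter), the first direct reading of a single change at this place, and it shows that the number here responds to the group on that oxygen. Neither group carries hydrogen-bond donors, hydrogen-bond acceptors or a net charge, so the change lies in the carbon part alone: fewer carbons and no ring. No evidence is available here on why the number rises.

From the compounds shown here alone, it remains open whether the ring or the carbon count matters more, since a cyclopentyl or a tert-butyl group on the same oxygen would help separate the two. The compounds shown also leave open whether this step would hold with a different rest of the molecule.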